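Removing the Methyl from an Amine Chain on a Shared Core

The source may hold more compounds than are shown below. What is called first, only, known or untested is meant among the compounds shown, and "the series" means these compounds.

Compound 1 `O=C(NCc1ccc(F)cc1)c1nc(Br)c2cccnc2c1NCc1ccccc1`: in a functional assay on HCT-116 cells (Homo sapiens) for cytotoxicity, read by MTT assay, with a stated time of 72 h (on this read-out higher numbers stand for weaker inhibition and lower numbers for stronger inhibition), compound 1 gives > 20000 nM, a limit of the assay and not a number.
Compound 2 `NCCCNc1c(C(=O)NCc2ccc(F)cc2)ncc2cccnc12`: in this assay compound 2 gives > 10000 nM, likewise a limit.
Compound 3 `CNCCCNc1c(C(=O)NCc2ccc(F)cc2)nc(Br)c2cccnc12`: in this assay compound 3 gives > 10000 nM, again a limit.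

Compound 3 therefore stands at a limit of this assay, with no number behind it; two of the three values sit at the limit of > 10000 nM in this assay, at which 2 of the 3 values shown sit, and one at the limit of > 20000 nM in this assay, at which 1 of the 3 values shown sits. Within the data shown here, the only measured step, a step that the two limits leave unreadable from compound 1 to compound 3, puts 2-(methylamino)ethyl in place of phenyl on a saturated chain carbon bound to a nitrogen on an aromatic ring, and its size cannot be read because the limit of > 10000 nM in this assay, at which 2 of the 3 values shown sit, and the limit of > 20000 nM in this assay, at which 1 of the 3 values shown sits, cap both of its ends.

Compound 4 `NCCCNc1c(C(=O)NCc2ccc(F)cc2)nc(Br)c2cccnc12` differs from compound 3 by hydrogen in place of methyl on an amine nitrogen: methyl leaves and hydrogen enters on an amine nitrogen whose other neighbour is a saturated chain carbon, so methylamino becomes amino. Among the measured compounds shown here, no measured step bears directly on this change. Compound 2, which also carries the amino chain, stands at a limit. The step that the limit leaves unreadable from compound 3 to compound 4 is thus expected to show no change beyond the scatter. In this assay compound 4 is estimated at 20000 nM, within 8000 nM to 60000 nM, most likely again reported only as a limit.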

Compound 4, half-maximal inhibitory concentration: 18000 nM
Compound 4: the middle estimate sits 1.1-fold (0.05 log units) above what was measured; measured number inside the range.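

In this assay, among these compounds, compound 4 gives 18000 nM, the only value that is a number and not a limit. The steps to compound 4 from compound 3 and from compound 2 cannot be read, so neither hydrogen in place of methyl on the amine nitrogen nor bromo in place of hydrogen on an aromatic carbon can be given a size. Among the compounds shown here, the one readable step is an at least 1.1-fold lower number from compound 1 to compound 4 (0.04 log units; that floor lies within the scatter), with 2-aminoethyl in place of phenyl on a saturated chain carbon bound to a nitrogen on an aromatic ring.

The compounds shown leave open how much, if at all, the value of compound 4 differs from that of compound 3. They also leave open what an ethyl group on this amine nitrogen, or a longer chain in place of 2-aminoethyl, would give in this assay.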